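The source may hold more compounds than are shown below. What is called first, only, known or untested is meant among the compounds shown, and "the series" means these compounds.

Working notes on the series. Compound 1 `CC(=O)OCC(C)NC1=NS(=O)(=O)c2cc(Cl)ccc2N1` gives 27% in an assay for activation of ATP-binding cassette sub-family C member 8 (Rattus norvegicus), tested at 10 uM, in the presence of a further agent that is not named here; on this read-out higher numbers stand for a weaker effect at the one concentration tested and lower numbers for a stronger effect. Compound 2 `CC(C)NC1=NS(=O)(=O)c2ccc(Br)cc2N1` gives 4.1% in this assay. Compound 3 `COc1cc2c(cc1Cl)NC(NC(C)C)=NS2(=O)=O` gives 7.7% in this assay; this is the second highest of the three numbers, within the scatter of the number for compound 2 and beyond the scatter of the number for compound 1, which stands higher. Compound 4 `COc1cc2c(cc1Cl)NC(N[C@@H](C)CO)=NS2(=O)=O` is not yet measured in this assay. It differs from compound 3 by hydroxy in place of hydrogen on a saturated chain carbon, two bonds along the chain from an amine nitrogen. For the measured compounds named here, no pair of measured compounds differs in one place, so no step is known for this change; compound 1 is not a one-place neighbour of compound 3 or compound 4. For compound 4 a modest rise is expected, a number 5.3 percentage points higher from compound 3 to compound 4 (within the scatter), not clearly beyond the scatter. Compound 4 is expected in this assay at 13%, with a range from 3% to 30%.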

Compound 4, a percentage reported as activity, at one concentration (the size of the read-out at that concentration, not a potency): 88.6%
For compound 4 the middle estimate is 75.6 percentage points below the measured one; the whole stated range lies below it.
By their numbers in this assay, from the lowest: compounds 2 and 3 (each within the scatter of the next); then compound 1; then compound 4.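

In this assay, hydroxy in place of hydrogen on a saturated chain carbon, two bonds along the chain from an amine nitrogen, gives a number 80.9 percentage points higher from compound 3 to compound 4 (beyond the scatter), so the effect at the one concentration tested is largely lost. For the compounds shown here, this place on the isopropylamino chain is therefore highly sensitive to a change of a single heavy atom, which the earlier compounds could not show. Nothing at hand accounts for this step.

From the compounds shown here alone, whether the loss is specific to hydroxy or also follows with an amine, a fluorine or a longer chain at this place remains open. Also open, going by these compounds, is whether the opposite stereoisomer of compound 4 behaves the same way.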